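The compounds below may be only part of what the source reports. "The series", "measured", "known", "first", "only" and "open" are said of these compounds alone.

Compound 1 `Cc1ccc(OCC(=O)N(Cc2cccs2)c2cccnc2)cc1` is examined in an assay on HEK293 cells for agonist activity at transient receptor potential cation channel subfamily M member 8 (Homo sapiens), read by fluorescence and calcium flux, with a stated time of 15 min (a higher number here means that more compound is needed for the effect, a lower number that less compound is needed), where compound 1 gives 198 nM. Of the two compounds measured in this assay it carries the lowest number: the only comparator, compound 2 `CCN(Cc1cccs1)C(=O)COc1ccccc1`, gives in this assay 1400 nM, a higher figure that lies beyond the usual scatter of repeated measurements. Compound 2 differs from compound 1 in more than one place, so its value serves only as a second point of reference, not as a single step.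

For the measured compounds named here, the step to compound 3 `Cc1ccc(OCC(=O)N(Cc2cccs2)c2ccccn2)cc1` keeps every atom and rearranges only one group: pyridin-2-yl in place of pyridin-3-yl on an amide-type nitrogen. Going by the values given here, no step of this kind between two measured compounds is known here, so the expectation rests on the change alone. The change from compound 1 to compound 3 is expected to be small, a 1.6-fold higher number from compound 1 to compound 3 (0.21 log units; within the scatter), with a slight shift toward a higher number, within or only just beyond the scatter. In this assay compound 3 is therefore estimated at 320 nM, with a likely range from 90 nM to 1200 nM.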

Compound 3, half-maximal effective concentration: 200 nM
The estimate for compound 3 lay 1.6-fold (0.20 log units) above the measured number; low and high end bracket the measured number.
By their numbers in this assay, from the lowest: compounds 1 and 3 (each within the scatter of the next); then compound 2.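

In this assay, pyridin-2-yl in place of pyridin-3-yl on the amide-type nitrogen gives a 1.0-fold higher number from compound 1 to compound 3 (0.00 log units; within the scatter), so this rearrangement leaves the number unchanged within the scatter. For the compounds shown here, this is the first single-place step available, since compound 2 differs from compound 1 in more than one place and could say nothing about this position alone. Nothing measured here explains why the two pyridinyl groups read alike.

The compounds shown leave open how far this insensitivity extends, for example whether a phenyl group or a pyridin-4-yl group on the same nitrogen would read the same. They also leave open whether the two pyridinyl groups would still match if the rest of the core of compound 1 changed, for instance with a methoxy group or a chlorine atom in place of its methyl group.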